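Replacing the bromo group of compound 2 with hydrogen

This account rests on a few compounds, and the source may have more. Where it says the series, first, only, none or still open, it means among the compounds named here.

Values so far in a functional assay on DU-145 cells (Homo sapiens) for cytotoxicity, read by MTT assay, with a stated time of 68 h; on this read-out higher numbers stand for weaker inhibition and lower numbers for stronger inhibition
compound 1 `O=C(/C=C/c1cccc(OCc2ccccc2)c1)c1ccc([N+](=O)[O-])cc1` gives 52500 nM
compound 2 `O=C(/C=C/c1cccc(OCc2ccccc2)c1)c1ccc(Br)cc1` gives 5700 nM
compound 3 `O=C(/C=C/c1cccc(OCc2ccccc2)c1)c1ccc(Cl)cc1` gives 43400 nM
compound 4 `O=C(/C=C/c1cccc(OCc2ccccc2)c1)c1ccccc1` is not yet measured

Compound 2 has the lowest number of the three in this assay and lies beyond the scatter from both others. The change hydrogen in place of bromo on an aromatic carbon turns compound 2 into compound 4, with hydrogen in place of bromo on an aromatic carbon. Two modest steps bear on it, namely a 7.6-fold higher number from compound 2 to compound 3 (0.88 log units; beyond the scatter) with bromo leaving and a 9.2-fold lower number from compound 1 to compound 2 (0.96 log units; beyond the scatter) with bromo entering. Among the compounds with values here, no measurement yet shows hydrogen at this place, so a step of similar size towards a higher number is expected. The estimate means a 5.3-fold higher number from compound 2 to compound 4 (0.72 log units; beyond the scatter) as the expected step. For compound 4 the estimated value is 30000 nM with 8000 nM to 80000 nM as its range.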

Compound 4, half-maximal inhibitory concentration: 42400 nM
For compound 4 the middle estimate is 1.4-fold (0.15 log units) below the measured one; measured number inside the range.
By their numbers in this assay, from the lowest: compound 2; then compounds 4, 3 and 1 (each within the scatter of the next).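

In this assay, hydrogen in place of bromo gives a clear step (a 7.4-fold higher number from compound 2 to compound 4 (0.87 log units; beyond the scatter)), so the low number of compound 2 depends on bromo at this place. Hydrogen is level with chloro (a 1.0-fold lower number from compound 3 to compound 4 (0.01 log units; within the scatter)) and with nitro (a 1.2-fold lower number from compound 1 to compound 4 (0.09 log units; within the scatter)), so of the four compounds only the bromo compound stands apart, and chloro and nitro show no gain over hydrogen. Nothing available accounts for bromo separating from chloro at this place.

Open, going by these compounds, is whether iodo or methoxy at this place would track bromo or hydrogen. Also open, on these data alone, is whether the gain from bromo persists with other changes on the shared core.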